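Adding a second methoxy to compound 1

This account rests on a few compounds, and the source may have more. Where it says the series, first, only, none or still open, it means among the compounds named here.

Compound 1 `COc1ccc(-c2cc(/C=C/C(=O)c3ccc(N)cc3)[nH]n2)cc1` and compound 2 `COc1ccc(C(=O)/C=C/c2cc(-c3cc(OC)c(OC)c(OC)c3)n[nH]2)cc1` share one core and differ in how their outer rings are substituted. In a functional assay on Hs-578T cells (Homo sapiens) for inhibition, read by sulforhodamine B assay, with a stated time of 48 h (a higher number here means a weaker inhibitor of growth, a lower number a stronger inhibitor of growth), compound 1 gives 4040 nM, and compound 2 gives 3600 nM. Compound 1 thus sits at the highest of the two numbers shown, with compound 2 the nearest, but the gap between them lies within the scatter, so the two cannot be told apart on these data.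

Compound 3 `COc1ccc(-c2cc(/C=C/C(=O)c3ccc(N)cc3)[nH]n2)cc1OC` has not been measured. It differs from compound 1 by methoxy in place of hydrogen on an aromatic carbon, the position being ortho to a methoxy group and meta to a large group. For the measured compounds named here, no measured pair shows this step, so its size can only be estimated. The expected step is a 1.3-fold lower number from compound 1 to compound 3 (0.13 log units; within the scatter) in this assay, a move that is not expected to reach beyond the scatter in either direction. For compound 3 the estimate in this assay is 3000 nM, with a range from 1000 nM to 9000 nM.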

Compound 3, concentration for 50% growth inhibition: 6570 nM
The estimate for compound 3 lay 2.2-fold (0.34 log units) below the measured number; the measured number falls inside the stated range.
By their numbers in this assay, from the lowest: compounds 2, 1 and 3 (each within the scatter of the next).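

In this assay the change to methoxy in place of hydrogen on an aromatic carbon, ortho to a methoxy group and meta to a large group, gives a 1.6-fold higher number from compound 1 to compound 3 (0.21 log units; within the scatter) and so does not separate the two compounds. For the compounds shown here, this is the only measured pair that isolates a single change, and on it the position accepts a second methoxy with no gain or loss that can be claimed. No measurement shown here bears on the reason for the size of this step.

As far as these compounds go, whether this position responds to a group other than methoxy, such as a hydroxyl, an amine or a longer alkoxy chain, remains open, as does the effect of removing the existing methoxy group. Also open, from the compounds shown here alone, is whether the same methoxy step would stay within the scatter with a different group on the other outer ring, for example a carboxylic acid in place of the amine of compound 1.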